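Amide in Place of Oxadiazolone: Expected Stability Shift

The compounds below may be only part of what the source reports. "The series", "measured", "known", "first", "only" and "open" are said of these compounds alone.

Compound 1 `CC(C)C(Cc1nnc[nH]1)c1ccc(-c2ccc3cccc(F)c3c2)[nH]c1=O` gives 0.1 h in an ADME assay on microsomes from liver (Rattus norvegicus) for metabolic stability; on this read-out lower numbers stand for a shorter-lived compound and higher numbers for a longer-lived compound. Compound 2 `Cc1nc(C(c2ccc(-c3ccc4cccc(F)c4c3)[nH]c2=O)C(C)C)[nH]c1C` gives 0.0733 h. Compound 3 `CC(C)C(Cc1noc(=O)[nH]1)c1ccc(-c2ccc3cccc(F)c3c2)[nH]c1=O` gives only a limit, > 3 h.

Compound 3 stands at the limit of this assay rather than at a number (the limit of > 3 h in this assay, at which 1 of the 3 values shown sits). Its two measured steps are both large: an at least 30-fold higher number from compound 1 to compound 3 (1.47 log units; beyond the scatter) and an at least 40-fold higher number from compound 2 to compound 3 (1.61 log units; beyond the scatter). Compound 1 and compound 2 sit within the scatter of each other, a 1.4-fold lower number from compound 1 to compound 2 (0.13 log units; within the scatter).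

Compound 4 `CC(C)C(CC(N)=O)c1ccc(-c2ccc3cccc(F)c3c2)[nH]c1=O` is not yet measured. It differs from compound 3 in one place: a group of 3 heavy atoms (1 carbon, 1 nitrogen, 1 oxygen; no ring) in place of a group of 6 heavy atoms (2 carbon, 2 nitrogen, 2 oxygen; one five-membered aromatic ring with 3 hetero atoms), on a saturated chain carbon, two bonds along the chain from an aromatic carbon. For the measured compounds named here, the two large steps into compound 3 both brought in the group that now leaves, so the step to compound 4 is expected to run the other way, toward the numbers of compound 1 and compound 2, though how far a carbamoyl group carries the number has no measured counterpart here. For compound 4 the expected step is an at least 6.0-fold lower number from compound 3 to compound 4 (0.77 log units; beyond the scatter), a drop beyond the scatter. Compound 4 is estimated at 0.5 h, between 0.1 h and 3 h.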

Compound 4, half-life: < 0.0667 h
Compound 4: a limit, no number (the forecaster's own chance of this, stated with the estimate: 20%); middle value at least 7.4-fold (0.87 log units) from the limit.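

In this assay, exchanging the ring group of compound 3 for carbamoyl gives an at least 44-fold lower number from compound 3 to compound 4 (1.65 log units; beyond the scatter), so at this place, on a saturated chain carbon, two bonds along the chain from an aromatic carbon, the high read-out of compound 3 is not kept by this small group without a ring. Carbamoyl also does not stand apart from the two other groups at the low end, with an at least 1.4-fold lower number from compound 1 to compound 4 (0.17 log units; that floor lies within the scatter) and an at least 1.0-fold lower number from compound 2 to compound 4 (0.04 log units; that floor lies within the scatter), both only floors. Compound 4 stands at a limit of the assay, not at a number: the limit of < 0.0667 h in this assay, at which 1 of the 4 values shown sits.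

Among the compounds shown, only compound 3 reaches the high end, so what in its ring group goes with that read-out stays unresolved. On these data alone, whether a carboxylic acid or a tetrazole at this place would join compound 3 or compound 4 remains open.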